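Methoxy addition on the aryl of the triazole series

A few compounds are considered here, and "the series" means these few. Any claim that something is new, unique, unknown or untested is made for them only; others in the source may bear on it.

Compound 3 `COc1ccc(-c2nnc(SCC(=O)Nc3ccc(/C(C)=N/O)cc3)n2-c2ccccc2)cc1` gives 45% in a functional assay on the whole organism (strain albino) for inhibition, with Rattus norvegicus as the target, read by paw edema, with stated times of 30 min and 1 h, at a dose of 0.28 mmol/kg by the oral route; a higher number here means more inhibition at the dose given (going by the name of the read-out), a lower number less inhibition. That is the lowest of the three numbers shown, though its gaps to the others are within the scatter: compound 1 `C/C(=N\O)c1ccc(NC(=O)CSc2nnc(-c3ccccc3)n2-c2ccccc2)cc1` gives 50%, and compound 2 `CCn1c(SCC(=O)Nc2ccc(/C(C)=N/O)cc2)nnc1-c1ccc(OC)c(OC)c1` gives 53%.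

Compound 4 `COc1ccc(-c2nnc(SCC(=O)Nc3ccc(/C(C)=N/O)cc3)n2-c2ccccc2)cc1OC` differs from compound 3 by methoxy in place of hydrogen on an aromatic carbon.

For the measured compounds named here, one measured step bears on this: the change from compound 1 to compound 3 is also a methoxy in place of hydrogen on an aromatic carbon, and it read a number 5 percentage points lower from compound 1 to compound 3 (within the scatter). Compound 2, which carries the 3,4-dimethoxyphenyl group but a different substituent on the shared core, shows a number close to that of compound 3, also within the scatter. Nothing in these data points to a step beyond the scatter for a second methoxy, so no movement of this assay beyond the scatter is expected.

Compound 4 is therefore expected to give about 48%, within 36% to 60%, an expected step of a number 3 percentage points higher from compound 3 to compound 4 (within the scatter).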

Compound 4, a percentage reported as inhibition, in the whole organism at one dose (the size of the read-out at that dose, not a potency): 57%
Beside the measured number, compound 4's estimate is 9 percentage points below it, within the range that was stated.
By their numbers in this assay, from the lowest: compounds 3, 1, 2 and 4 (each within the scatter of the next, the first and the last beyond it).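

For the compounds shown here, a second methoxy, ortho to a methoxy group, turns 4-methoxyphenyl into 3,4-dimethoxyphenyl and in this assay gives a number 12 percentage points higher from compound 3 to compound 4 (beyond the scatter) as the first step in these compounds to pass the scatter, while the first methoxy gave a number 5 percentage points lower from compound 1 to compound 3 (within the scatter) and stayed within it. The change of phenyl to 3,4-dimethoxyphenyl gives a number 7 percentage points higher from compound 1 to compound 4 (within the scatter) and the change of ethyl to phenyl on the aromatic nitrogen gives a number 4 percentage points higher from compound 2 to compound 4 (within the scatter) and both stay within the scatter, so the second methoxy separates compound 4 only from compound 3. No measurement shown here accounts for this step.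

On these data alone, whether the step belongs to methoxy itself or would also appear with a hydroxyl, an amine or an ethoxy at this place stays open. As far as these compounds go, whether it carries over with ethyl on the aromatic nitrogen also stays open.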